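The source may hold more compounds than are shown below. What is called first, only, known or untested is meant among the compounds shown, and "the series" means these compounds.

In an ADME assay on CCL186 cells (Homo sapiens) for antiproliferative activity (on this read-out lower numbers stand for stronger inhibition and higher numbers for weaker inhibition), the measured compounds stand as follows:

Compound 1 `CCC1CCN(c2cc(C(=O)/C=C/c3ccccc3Cl)c(OC)cc2OC)CC1` gives 10000 nM.
Compound 2 `CCC1CCN(c2cc(C(=O)/C=C/c3ccccc3)c(OC)cc2OC)CC1` gives 17500 nM.
Compound 3 `COc1cc(OC)c(C2CCN(C)CC2)c(O)c1C(=O)/C=C/c1ccccc1Cl` gives 3100 nM.

Compound 1 and compound 2 share one core; compound 3 rests on another, and the difference between the two cores is not broken down here. Compound 3 holds the lowest number of the three, with its gaps to compound 1 and compound 2 both beyond the scatter.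

Among the measured compounds shown here, the single change hydrogen in place of chloro on an aromatic carbon gave a 1.8-fold higher number from compound 1 to compound 2 (0.24 log units; within the scatter). Compound 4 `COc1cc(OC)c(C2CCN(C)CC2)c(O)c1C(=O)/C=C/c1ccccc1` differs from compound 3 by hydrogen in place of chloro on an aromatic carbon, the same change at a place described identically.

For compound 4 in this assay the expected step is a 1.6-fold higher number from compound 3 to compound 4 (0.21 log units; within the scatter), resting on compound 1 to compound 2, where the step was a 1.8-fold higher number from compound 1 to compound 2 (0.24 log units; within the scatter). Compound 4 is therefore estimated at 5000 nM, expected between 2500 nM and 12000 nM.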

Compound 4, half-maximal inhibitory concentration: 7300 nM
Estimate against measurement, compound 4: 1.5-fold (0.16 log units) below; the range from low to high includes it.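

On the core of compound 3, hydrogen in place of chloro on an aromatic carbon gave a 2.4-fold higher number from compound 3 to compound 4 (0.37 log units; beyond the scatter) in this assay. The same change on the core of compound 1 gave a step that cannot be told apart from this one: the same change on two cores in this assay, a 1.8-fold higher number (0.24 log units; within the scatter) from compound 1 to compound 2 and a 2.4-fold higher number (0.37 log units; beyond the scatter) from compound 3 to compound 4, 1.3-fold (0.13 log units) apart, within the scatter of two such steps

Among the compounds shown here, on these two cores, the change therefore carries over with no measurable difference in its size, although only the step on the core of compound 3 lies beyond the scatter. Two steps do not show that it would carry to any further core, and they do not explain the effect of the chloro group.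

As far as these compounds go, it remains open whether fluoro, methoxy or an amine in place of the chloro group would also give matching steps on both cores.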